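This account rests on a few compounds, and the source may have more. Where it says the series, first, only, none or still open, it means among the compounds named here.

Of the compounds shown here, three have been measured in an assay on isolated protein for displacement of a labelled ligand from Gonadotropin-releasing hormone receptor (Rattus norvegicus); on this read-out lower numbers stand for stronger inhibition and higher numbers for weaker inhibition. Compound 1 `Cn1cnc(CN2CCN(c3cccc4[nH]c(-c5ccc(C(C)(C)C)cc5)nc34)CC2)c1` gives 98 nM. Compound 2 `CCCn1cnc(CN2CCN(c3cccc4[nH]c(-c5ccc(C(C)(C)C)cc5)nc34)CC2)c1C` gives 47 nM, and compound 3 `Cc1nc(CN2CCN(c3cccc4[nH]c(-c5ccc(C(C)(C)C)cc5)nc34)CC2)cn1C` gives 34 nM. Compound 3 stands at the lowest number of the three: the step of a 2.9-fold lower number from compound 1 to compound 3 (0.46 log units; beyond the scatter) lies beyond the scatter, whereas a 1.4-fold lower number from compound 2 to compound 3 (0.14 log units; within the scatter) does not, so compound 2 and compound 3 cannot be ordered against each other. The step of a 2.1-fold lower number from compound 1 to compound 2 (0.32 log units; beyond the scatter) is modest as well.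

Compound 4 `CCc1nc(CN2CCN(c3cccc4[nH]c(-c5ccc(C(C)(C)C)cc5)nc34)CC2)cn1C` has not yet been measured. It differs from compound 3 by methyl in place of hydrogen on a saturated chain carbon bound to an aromatic carbon. Within the data shown here, no measured step makes the same change, methyl in place of hydrogen on a saturated chain carbon bound to an aromatic carbon. The nearest in kind is a 2.9-fold lower number from compound 1 to compound 3 (0.46 log units; beyond the scatter), a methyl added to an aromatic carbon, and the broader change a 1.4-fold lower number from compound 2 to compound 3 (0.14 log units; within the scatter) stayed within the scatter. Every measured step on this part of the molecule was modest, so for compound 4 the expected step of a 1.1-fold lower number from compound 3 to compound 4 (0.05 log units; within the scatter) is none beyond the scatter. The estimate for compound 4 in this assay is 30 nM, with a range from 12 nM to 75 nM.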

Compound 4, half-maximal inhibitory concentration: 78 nM
Beside the measured number, compound 4's estimate is 2.6-fold (0.41 log units) below it; the whole stated range lies below it.
By their numbers in this assay, from the lowest: compounds 3, 2, 4 and 1 (each within the scatter of the next, the first and the last beyond it).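

Extending the methyl of the 1,2-dimethyl-1H-imidazol-4-yl group to ethyl gives, in this assay, a 2.3-fold higher number from compound 3 to compound 4 (0.36 log units; beyond the scatter) as the result at this position, so the lower number seen with a methyl on this aromatic carbon does not carry over to ethyl. Against hydrogen on the same carbon, ethyl gives a 1.3-fold lower number from compound 1 to compound 4 (0.10 log units; within the scatter) and so shows no gain beyond the scatter, leaving methyl as the only group here with a step beyond it. The step of a 1.7-fold higher number from compound 2 to compound 4 (0.22 log units; within the scatter) also stays within the scatter, so compound 4 cannot be ordered against compound 2. No measurement on hand accounts for the methyl-to-ethyl step.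

Going by these compounds, whether a longer chain such as propyl, a branched isopropyl or a cyclopropyl goes further in the same direction remains open. So does the outcome with a hydroxymethyl or aminomethyl group on this carbon.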